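This account rests on a few compounds, and the source may have more. Where it says the series, first, only, none or still open, it means among the compounds named here.

Measured so far:
Compound 1 `Fc1ccc(-c2cn3ccnc3c(-c3ccc4ncn(C5CCCCC5)c4c3)n2)cc1`; in a functional assay on SW-620 cells (Homo sapiens) for inhibition, read by sulforhodamine B assay, with a stated time of 48 h, tested at 10 uM (on this read-out higher numbers stand for more inhibition at the one concentration tested (going by the name of the read-out) and lower numbers for less inhibition), compound 1 gives 8.38%.
Compound 2 `Brc1ccc(-c2cn3ccnc3c(-c3ccc4ncn(C5CCCCC5)c4c3)n2)cc1`; in this assay compound 2 gives 21.9%.

Compound 2 stands highest of the two numbers; its nearest neighbour is compound 1, separated by a number 13.5 percentage points higher from compound 1 to compound 2 (beyond the scatter).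

Compound 3 `Fc1ccccc1-c1cn2ccnc2c(-c2ccc3ncn(C4CCCCC4)c3c2)n1` is not yet measured. Against compound 2 the change is 2-fluorophenyl in place of 4-bromophenyl on an aromatic carbon. Among the compounds with values here, the only measured step that bears on this change is a number 13.5 percentage points higher from compound 1 to compound 2 (beyond the scatter), bromo in place of fluoro on an aromatic carbon. Within the data shown here, compound 3 goes back to fluoro, so part of that step is expected to reverse; the fluoro now sits in a 2-fluorophenyl rather than as in compound 1, and no measured pair shows what that shift does, so the reversal is taken as partial to full. The step in this assay is expected to be a number 10.9 percentage points lower from compound 2 to compound 3 (beyond the scatter). For compound 3 the estimate in this assay is 11%, between 0% and 25%.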

Compound 3, a percentage reported as inhibition, at one concentration (the size of the read-out at that concentration, not a potency): 9.53%
Estimate against measurement, compound 3: 1.5 percentage points above; the measured number falls inside the stated range.
By their numbers in this assay, from the lowest: compounds 1 and 3 (each within the scatter of the next); then compound 2.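

In this assay, the shift from 4-fluorophenyl to 2-fluorophenyl leaves the read-out unresolved, with a number 1.2 percentage points higher from compound 1 to compound 3 (within the scatter), so the place of the fluoro on this phenyl ring has no visible effect here. Compound 2 now stands apart from both fluoro compounds, with a number 12.4 percentage points lower from compound 2 to compound 3 (beyond the scatter), in the same direction as a number 13.5 percentage points higher from compound 1 to compound 2 (beyond the scatter); among these three compounds, the higher number goes with the 4-bromophenyl group alone. No measured information explains the difference.

Open, on these data alone, is whether the bromo keeps its higher number on the 2-fluorophenyl position, as a 2-bromophenyl group, or whether the step follows the halogen at all. As far as these compounds go, how a methoxy group, an amine or a carboxylic acid on the phenyl ring would read here also remains unknown.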